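The source may report more compounds than this note shows. Statements on the series, on what has been measured and on what is new or still open speak of the compounds shown alone.

Compound 1 `CN(c1ccc(NC(=O)c2cc(C(F)(F)F)cc(C(F)(F)F)c2)cc1OCc1cccc(C(F)(F)F)c1)S(C)(=O)=O` sits at a limit in an ADME assay on HEK293 cells (Homo sapiens) for cytotoxicity, read by MTT assay, with a stated time of 48 h (a higher number here means a weaker inhibitor, a lower number a stronger inhibitor), giving > 500000 nM. Two of the three values reported so far stand at that same limit (the limit of > 500000 nM in this assay, at which 2 of the 3 values shown sit). Compound 2 `CN(c1ccc(NC(=O)c2cc(C(F)(F)F)cc(C(F)(F)F)c2)cc1OCc1cccc(C(F)(F)F)c1)S(=O)(=O)Cc1ccccc1` gives 59800 nM in this assay. Compound 3 `CN(c1ccc(NC(=O)c2cc(C(F)(F)F)cc(C(F)(F)F)c2)cc1OCc1ccccc1C(F)(F)F)S(=O)(=O)Cc1ccccc1` again returns only a limit, > 500000 nM. The measured steps are an at least 8.3-fold lower number from compound 1 to compound 2 (0.92 log units; beyond the scatter) and an at least 8.3-fold higher number from compound 2 to compound 3 (0.92 log units; beyond the scatter); neither touches the exchange in hand. Compound 4 `CN(c1ccc(NC(=O)c2cc(C(F)(F)F)cc(C(F)(F)F)c2)cc1OCc1cccc(C(=N)N)c1)S(C)(=O)=O` differs from compound 1 by a group of 3 heavy atoms (1 carbon, 2 nitrogen; no ring) in place of a group of 4 heavy atoms (1 carbon, 3 fluorine; no ring), on an aromatic carbon. For the measured compounds named here, no measured step bears directly on this change on the six-membered aromatic ring of carbon only, so no size can be read across; with compound 1 at a limit in this assay, a value at or near that limit is expected for compound 4. Compound 4 is estimated at 500000 nM (range 100000 nM to 1000000 nM), an expected step of a number no higher from compound 1 to compound 4 (the limit leaves the size open).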

Compound 4, half-maximal inhibitory concentration: > 500000 nM
Compound 4: only a limit was reported (the forecaster's own chance of this, stated with the estimate: 70%); the middle value lies on the limit itself.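

Compound 4 returns only a limit in this assay, > 500000 nM, and compound 1 is also a limit, so no step can be read from compound 1 to compound 4: the limit of > 500000 nM in this assay, at which 3 of the 4 values shown sit.

The compounds shown leave open what size of effect, if any, replacing trifluoromethyl with the group in compound 4 has.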